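This account rests on a few compounds, and the source may have more. Where it says the series, first, only, none or still open, it means among the compounds named here.

Measured compounds:
compound 1 `Brc1ccc2ccn(CCN3CCCN4CCCCC4C3)c2c1`: 99%
compound 2 `CN1CCCN(CCn2ccc3cc(Br)ccc32)CC1`: 65%
compound 3 `CN1CCCN(CCn2ccc3ccc(F)cc32)CC1`: 60%

In an assay on HEK293 cells for binding affinity to 5-hydroxytryptamine receptor 7 (Homo sapiens), read by radioligand binding, tested at 1 uM (on this read-out higher numbers stand for more inhibition at the one concentration tested (going by the name of the read-out) and lower numbers for less inhibition), compound 1 gives 99%, compound 2 gives 65% and compound 3 gives 60%. Compound 3 has the lowest of the three numbers, but its gap to compound 2 lies within the usual scatter, whereas compound 1 stands beyond the scatter above it. Compound 4 `Cc1ccc2ccn(CCN3CCCN(C)CC3)c2c1` has not yet been measured. It differs from compound 3 in one place: methyl in place of fluoro on an aromatic carbon. Among the measured compounds shown here, no measured pair shows this exchange, so its effect is unknown from the data. The change is small in count, one heavy atom leaving and one entering, so the step in this assay is expected to stay within the scatter, with no clear direction. Compound 4 is therefore expected to give 60%, within a range from 40% to 80%. That corresponds to an expected step of no change at the digits printed from compound 3 to compound 4 (within the scatter).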

Compound 4, a percentage reported as inhibition, at one concentration (the size of the read-out at that concentration, not a potency): 62%
Compound 4: the middle estimate sits 2 percentage points below what was measured, and the stated range covers the measured number.
By their numbers in this assay, from the lowest: compounds 3, 4 and 2 (each within the scatter of the next); then compound 1.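

In this assay, methyl in place of fluoro on an aromatic carbon gives a number 2 percentage points higher from compound 3 to compound 4 (within the scatter), so at this position the two groups cannot be told apart at the one concentration tested. Among the compounds shown here, this is the first pair here that differs in one place, and so the first direct reading of a single exchange on this ring. Nothing measured here bears on the reason for this result.

On these data alone, whether a larger group on this carbon, such as methoxy or trifluoromethyl, would also fall within the scatter remains open. So does the effect of an amine there.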